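Amide Substituent Change and Rat Hepatocyte Clearance

The source may report more compounds than this note shows. Statements on the series, on what has been measured and on what is new or still open speak of the compounds shown alone.

Of the compounds shown here, two of a shared core have been measured in an ADME assay on cells (Hepatocyte, Rattus norvegicus) for metabolic stability; on this read-out higher numbers stand for fast clearance and lower numbers for slow clearance. Compound 1 `O=C(N[C@H]1CN(S(=O)(=O)c2ccccc2)C[C@@H]1C(=O)N1C[C@H]2CCNC[C@H]21)c1cc(-c2ccccc2Cl)on1` gives 4.7 uL/min. Within the data shown here, compound 2 `O=C(N[C@H]1CN(S(=O)(=O)c2ccccc2)C[C@@H]1C(=O)NC[C@@H]1CCCN1)c1cc(-c2ccccc2Cl)on1` gives 22 uL/min, the highest of the two numbers, and the only step so far is a 4.7-fold higher number from compound 1 to compound 2 (0.67 log units; beyond the scatter). That step concerns an exchange on a carbonyl carbon. Compound 3 `CN1CCC[C@H](NC(=O)[C@H]2CN(S(=O)(=O)c3ccccc3)C[C@@H]2NC(=O)c2cc(-c3ccccc3Cl)on2)C1` is not yet measured. It differs from compound 2 by 1-methylpiperidin-3-yl in place of (pyrrolidin-2-yl)methyl on an amide-type nitrogen, that is, a (pyrrolidin-2-yl)methyl leaves and a 1-methylpiperidin-3-yl enters on an amide-type nitrogen whose other neighbour is a carbonyl carbon. The step of a 4.7-fold higher number from compound 1 to compound 2 (0.67 log units; beyond the scatter) is the only one that bears on this region of the molecule, and it concerned a different exchange, so it gives direction only loosely. Among the measured compounds shown here, no measured pair shows this exact change. Compound 3 is therefore expected to stay near compound 2, with a step of a 1.2-fold lower number from compound 2 to compound 3 (0.09 log units; within the scatter) that may fall within the scatter. The estimate for compound 3 in this assay is 18 uL/min, with a range from 6 uL/min to 50 uL/min.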

Compound 3, intrinsic clearance in a liver preparation (reported as CLH), per the amount of preparation that the assay uses: 31 uL/min
The estimate for compound 3 lay 1.7-fold (0.24 log units) below the measured number, within the range that was stated.
By their numbers in this assay, from the lowest: compound 1; then compounds 2 and 3 (each within the scatter of the next).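

In this assay, 1-methylpiperidin-3-yl in place of (pyrrolidin-2-yl)methyl on the amide-type nitrogen gives a 1.4-fold higher number from compound 2 to compound 3 (0.15 log units; within the scatter) and so leaves the read-out within the usual scatter, even though the two groups differ in ring size and in their count of hydrogen-bond donors. Compound 1 now stands apart from two compounds rather than one: the comparison with the new compound gives a 6.6-fold higher number from compound 1 to compound 3 (0.82 log units; beyond the scatter) and agrees in direction and rough size with the step already seen for compound 2, so among these three compounds the two groups with a single ring sit together and the group with a four-membered and a six-membered ring has the lowest number. The compounds shown offer no measurement that accounts for either step.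

Ring size, the attachment of the ring and the methyl group all change together from compound 2 to compound 3, so their separate contributions cannot be read. As far as these compounds go, it remains open how a piperidin-3-yl without the methyl group, or an open-chain group such as 2-aminoethyl, would read on the same amide-type nitrogen.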